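The source may report more compounds than this note shows. Statements on the series, on what has been measured and on what is new or still open speak of the compounds shown alone.

Measured so far:
compound 1, `CC(=O)Nc1cc(Nc2cc(NC3CC3)n3ncc(C#N)c3n2)ccc1NCCCO` — in an ADME assay on cells (Hepatocyte, Rattus norvegicus) for metabolic stability (on this read-out lower numbers stand for slow clearance and higher numbers for fast clearance), compound 1 gives 17 uL/min
compound 2, `CC(=O)Nc1cc(Nc2cc(NC3CC3)n3ncc(C#N)c3n2)ccc1N1CC[C@@H](N)C1` — in this assay compound 2 gives 2.5 uL/min

Of these two, compound 2 stands at the lower number; the step of a 6.8-fold lower number from compound 1 to compound 2 (0.83 log units; beyond the scatter) tells how far it lies from compound 1.

Compound 3, `CC(=O)Nc1cc(Nc2cc(NC3CC3)n3ncc(C#N)c3n2)ccc1N1CC[C@H](N)C1`, has not been measured. Compared with compound 2, it shows (the two compounds have the same atoms and bonds and differ only in configuration as drawn: 1 of 1 stereo elements differ; a stereocentre at a saturated ring carbon is drawn R in compound 2 and S in compound 3). The same atoms and bonds are present; only the configuration at that ring carbon is drawn the other way round.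

For the measured compounds named here, only one measured step exists, and it concerns a different kind of change: a 3-aminopyrrolidin-1-yl entering in place of a (3-hydroxypropyl)amino group. Nothing measured here speaks to what turning the configuration at one saturated ring carbon does in this assay. Without a step that bears on the change, the plain expectation is that compound 3 stays close to compound 2, with a change of no change at the digits printed from compound 2 to compound 3 (within the scatter) expected, which is none beyond the scatter. For compound 3 a value of 2.5 uL/min is therefore estimated, most likely between 1 uL/min and 6.5 uL/min.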

Compound 3, intrinsic clearance in a liver preparation (reported as CLH), per the amount of preparation that the assay uses: < 1 uL/min
Compound 3: no number, only a limit; the forecaster's own chance of this, stated with the estimate: 5%; at least 2.5-fold (0.39 log units) between middle value and limit.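

In this assay compound 3 gives < 1 uL/min, and this is a limit of the assay rather than a number: the limit of < 1 uL/min in this assay, at which 1 of the 3 values shown sits.

Turning the configuration at a single saturated ring carbon of the 3-aminopyrrolidin-1-yl group, from R to S, is enough to give an at least 2.5-fold lower number from compound 2 to compound 3 (0.39 log units; beyond the scatter), so at this position the read-out responds to the spatial arrangement alone and not only to which group is attached: the fact that compounds 2 and 3 differ only in the configuration as drawn

Placing the S form of the 3-aminopyrrolidin-1-yl group where the (3-hydroxypropyl)amino group stood gives an at least 17-fold lower number from compound 1 to compound 3 (1.23 log units; beyond the scatter), whereas the R form gives a 6.8-fold lower number from compound 1 to compound 2 (0.83 log units; beyond the scatter).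

As far as these compounds go, how far the step to compound 3 truly reaches remains open, as only its minimum can be read from a limit. From the compounds shown here alone, it is also open whether turning the configuration would matter in the same way with a hydroxyl group in place of the amine on the pyrrolidine ring, or with a methylamino group there.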